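Hydroxy Added to Compound 1: Expected Cytotoxicity Outcome

The source may report more compounds than this note shows. Statements on the series, on what has been measured and on what is new or still open speak of the compounds shown alone.

Compound 1 `Cc1cc(NC(=O)Nc2ccc(C(=O)O)cc2)c2ccccc2n1` was tested in an ADME assay on HEK293 cells (Homo sapiens) for cytotoxicity, with a stated time of 72 h; on this read-out lower numbers stand for an effect already at smaller amounts and higher numbers for an effect only at larger amounts of compound. Compound 1 gives > 25000 nM, which is a limit of the assay and not a number. Compound 2 `Cc1ccc(NC(=O)Nc2cc(C)nc3ccccc23)cc1` differs from compound 1 by methyl in place of carboxy on an aromatic carbon. In this assay compound 2 gives > 25000 nM, again a limit rather than a number. The step that the two limits leave unreadable from compound 1 to compound 2 therefore cannot be sized. Where compound 1 stands is known only as a limit, because of the limit of > 25000 nM in this assay, at which 2 of the 2 values shown sit.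

Compound 3 `Cc1cc(NC(=O)Nc2ccc(C(=O)O)c(O)c2)c2ccccc2n1` is not yet measured. Compared with compound 1 the change is hydroxy in place of hydrogen on an aromatic carbon. Among the measured compounds shown here, the only measured step, from compound 1 to compound 2, is unreadable, and no measured step gives guidance on the size or direction of this change in this assay. With compound 1 at its limit, the step that the limit leaves unreadable from compound 1 to compound 3 is estimated as essentially none beyond the scatter. Compound 3 is expected to give 40000 nM, with a range from 15000 nM to 100000 nM.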

Compound 3, half-maximal effective concentration: > 25000 nM
Compound 3 was reported as a limit (the forecaster's own chance of this, stated with the estimate: 85%); the middle value lies beyond the limit too.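

No step can be read between compound 1 and compound 3, since both results are limits of the assay and not numbers: the limit of > 25000 nM in this assay, at which 3 of the 3 values shown sit.

The compounds shown leave open whether any change to the shared core would give a measurable effect in this assay, and at what concentration.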